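Swapping Chloro for Amino on a Shared Core

The compounds below may be only part of what the source reports. "The series", "measured", "known", "first", "only" and "open" are said of these compounds alone.

Compound 1, `Nc1nn(C(=O)Nc2ccc(Cc3ccccc3)cc2)c2ccccc12`, was tested in a functional assay on OVCAR-8 cells (Homo sapiens) for antiproliferative activity, read by sulforhodamine B assay, with a stated time of 48 h; a lower number here means that less compound is tolerated, a higher number that more compound is tolerated. In this test compound 1 gives > 100000 nM, which is a limit of the assay rather than a measured number. Compound 2, `Nc1nn(C(=O)Nc2ccc(Cc3ccccc3)cc2)c2ccc(Cl)cc12`, carries chloro in place of hydrogen on an aromatic carbon. In this assay compound 2 gives > 100000 nM, again a limit rather than a number. The step that the two limits leave unreadable from compound 1 to compound 2 therefore cannot be sized, the reason being (the limit of > 100000 nM in this assay, at which 2 of the 2 values shown sit). Compound 2 thus stands only at that limit, with no number attached. The unmeasured compound 3, `Nc1ccc2c(c1)c(N)nn2C(=O)Nc1ccc(Cc2ccccc2)cc1`, differs from compound 2 by amino in place of chloro on an aromatic carbon. For the measured compounds named here, the only measured step that bears on this change is the unreadable one, so nothing shows a substituent on this carbon pulling the result past the limit. The expected step that the limit leaves unreadable from compound 2 to compound 3 is therefore none beyond the scatter, most likely another limit. Compound 3 is estimated at 120000 nM, with a range from 40000 nM to 400000 nM.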

Compound 3, concentration lethal to 50% of the cells: > 100000 nM
Compound 3 ended at the assay's limit; the forecaster's own chance of this, stated with the estimate: 75%; the middle value lies beyond the limit too.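

For the compounds shown here, the result for compound 3 is again a limit rather than a number, so no step among compound 1, compound 2 and compound 3 can be read: the limit of > 100000 nM in this assay, at which 3 of the 3 values shown sit. In this assay these compounds leave open whether any group on this aromatic carbon gives a measurable value.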